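This account rests on a few compounds, and the source may have more. Where it says the series, first, only, none or still open, it means among the compounds named here.

Compound 1 `O=C(NNC(=O)C1CC1c1ccc(OC(F)(F)F)cc1)c1ccncc1`: in a functional assay on SK-MEL cells (Homo sapiens) for inhibition, read by MTT assay, with a stated time of 72 h (on this read-out lower numbers stand for stronger inhibition and higher numbers for weaker inhibition), compound 1 is recorded as "not determined" (no result reported).
Compound 2 `COc1ccc(C2CC2C(=O)NNc2nncc3ccccc23)cc1`: in this assay compound 2 gives 68000 nM.

Among the compounds with values here, compound 2 therefore stands alone on the numbers: it is the only compound with a half-maximal inhibitory concentration in this assay, and compound 1 is present only as an entry without a number, so no ranking between the two can be drawn.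

Compound 3 `CC(C)=CCOc1ccc(C2CC2C(=O)NNc2nncc3ccccc23)cc1` arises from compound 2 by one change, (2-methylprop-1-en-1-yl in place of hydrogen on a saturated chain carbon bound to an oxygen on an aromatic ring). Within the data shown here, no pair of measured compounds shows what this change does in this assay, so the size of the step can only be estimated from the change itself. The step expected from compound 2 to compound 3 is a 1.7-fold lower number from compound 2 to compound 3 (0.23 log units; within the scatter), a shift toward stronger inhibition that is not expected to lie far beyond the usual scatter. Compound 3 is accordingly estimated at 40000 nM, with a range from 10000 nM to 120000 nM.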

Compound 3, half-maximal inhibitory concentration: 67000 nM
For compound 3 the middle estimate is 1.7-fold (0.22 log units) below the measured one; measured number inside the range.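

In this assay, putting 2-methylprop-1-en-1-yl in place of hydrogen on a saturated chain carbon bound to an oxygen on an aromatic ring gives a 1.0-fold lower number from compound 2 to compound 3 (0.01 log units; within the scatter) and so leaves compound 2 and compound 3 indistinguishable on this read-out. Within the data shown here, this is the first measured reading at this position: extending methoxy to (3-methylbut-2-en-1-yl)oxy, which adds a double bond outside the aromatic rings, produces no step beyond the usual scatter. No measurement offered here bears on why the number holds.

From the compounds shown here alone, it remains open whether a different group on this oxygen, such as an amine or a carboxylic acid on the chain, or a longer saturated chain, would move the number. Going by these compounds, it is equally open how changes elsewhere on the shared core of compound 2 would read in this assay.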